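Compound 3: hydrogen in place of trifluoromethyl

A few compounds are considered here, and "the series" means these few. Any claim that something is new, unique, unknown or untested is made for them only; others in the source may bear on it.

Going by the values given here, in a functional assay on K562 cells (Homo sapiens) for inhibition, read by sulforhodamine B assay, with a stated time of 48 h (on this read-out higher numbers stand for weaker inhibition of growth and lower numbers for stronger inhibition of growth), compound 1 `COc1cc(-c2nn(-c3cccc(NC(=O)Nc4cc(C(F)(F)F)cc(C(F)(F)F)c4)c3)cc2-c2ccncc2)ccc1Cl` gives 363 nM, the lowest of the two numbers so far. Compound 2 `COc1cc(-c2nn(-c3cccc(NC(=O)Nc4ccc(Cl)c(Cl)c4)c3)cc2-c2ccncc2)ccc1Cl` gives 890 nM, a higher number, and this gap lies beyond the scatter. Compound 3 `COc1cc(-c2nn(-c3cccc(NC(=O)Nc4cccc(C(F)(F)F)c4)c3)cc2-c2ccncc2)ccc1Cl` is still unmeasured. It departs from compound 1 by hydrogen in place of trifluoromethyl on an aromatic carbon, with hydrogen in place of trifluoromethyl on an aromatic carbon, and a trifluoromethyl group remains on that ring. Among the compounds with values here, no measured pair isolates this change, so any forecast is weakly anchored. Within the data shown here, compound 2 and compound 1 show only that the numbers can shift with the substituents on this ring. A moderate move towards weaker inhibition of growth in this assay is expected, and it may only just clear the scatter. The expected change is a 2.2-fold higher number from compound 1 to compound 3 (0.34 log units; beyond the scatter). For compound 3 the estimated value is 800 nM, with an expected range of 300 nM to 2200 nM.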

Compound 3, concentration for 50% growth inhibition: 584 nM
Compound 3: the middle estimate sits 1.4-fold (0.14 log units) above what was measured; the range from low to high includes it.
By their numbers in this assay, from the lowest: compounds 1, 3 and 2 (each within the scatter of the next, the first and the last beyond it).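

In this assay the exchange of one trifluoromethyl group for hydrogen gives a 1.6-fold higher number from compound 1 to compound 3 (0.21 log units; within the scatter) and so does not resolve the two groups at this aromatic carbon while the other trifluoromethyl group stays on the ring. The exchange of 3,4-dichlorophenyl for 3-(trifluoromethyl)phenyl on the amide-type nitrogen gives a 1.5-fold lower number from compound 2 to compound 3 (0.18 log units; within the scatter) and likewise resolves nothing, so this single-trifluoromethyl ring sits within the scatter of both the other rings, though those two lie beyond the scatter of each other. No measurement on hand accounts for either step.

The compounds shown leave open whether the remaining trifluoromethyl group could also give way to hydrogen without a clear shift in this assay. They also leave open how a nitrile, an amine or a carboxylic acid would read at this aromatic carbon.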